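From isopropyl to tert-butyl: compound 2 and compound 4

A few compounds are considered here, and "the series" means these few. Any claim that something is new, unique, unknown or untested is made for them only; others in the source may bear on it.

- Compound 1 `C=CCNC(=O)[C@@H](NC(=O)[C@@](O)(CCCN(Cc1ccc(Br)cc1)NC(=O)[C@@H](NC(=O)OC)C(C)(C)C)Cc1ccc(CC=C)cc1)C(C)(C)C` gives > 50000 nM as a limit of the assay
- Compound 2 `C=CCNC(=O)[C@@H](NC(=O)[C@](O)(CCCN(Cc1ccc(Br)cc1)NC(=O)[C@@H](NC(=O)OC)C(C)(C)C)Cc1ccc(Br)cc1)C(C)C` gives 4500 nM
- Compound 3 `COC(=O)N[C@H](C(=O)NN(CCC[C@@]1(O)Cc2ccc(cc2)C/C=C\CNC(=O)[C@H](C(C)(C)C)NC1=O)Cc1ccc(Br)cc1)C(C)(C)C` gives 30000 nM

In an ADME assay on MT4 cells (Homo sapiens) for cytotoxicity, read by XTT assay, with a stated time of 5 days (on this read-out higher numbers stand for lower toxicity in this test and lower numbers for higher toxicity in this test), compound 2 holds the lower of the two true numbers at 4500 nM, and compound 3 stands higher at 30000 nM, a gap beyond the usual scatter. Compound 1 reports > 50000 nM, which is a limit and not a number.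

Compound 4 `C=CCNC(=O)[C@@H](NC(=O)[C@](O)(CCCN(Cc1ccc(Br)cc1)NC(=O)[C@@H](NC(=O)OC)C(C)(C)C)Cc1ccc(Br)cc1)C(C)(C)C` matches compound 2 except at one place: methyl in place of hydrogen on a saturated chain carbon bound to three saturated chain carbons. In words, isopropyl becomes tert-butyl. Going by the values given here, no measured pair here differs in only one place, so this change has no direct precedent. Compound 1 and compound 3 both carry tert-butyl at that place, but both also differ from compound 2 elsewhere, so they offer only a loose guide. Compound 3 gives 30000 nM with tert-butyl, which makes a rise in this assay the likelier direction, though probably not the full distance to that value. The expected change, upward and beyond the scatter, is a 2.2-fold higher number from compound 2 to compound 4 (0.35 log units; beyond the scatter). For compound 4 the estimate is 10000 nM, with an expected range from 3500 nM to 30000 nM.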

Compound 4, half-maximal cytotoxic concentration: 21000 nM
Beside the measured number, compound 4's estimate is 2.1-fold (0.32 log units) below it; low and high end bracket the measured number.
By their numbers in this assay, from the lowest: compound 2; then compounds 4 and 3 (each within the scatter of the next). At a limit, above all of these: compound 1.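

The change from isopropyl to tert-butyl, on a saturated chain carbon bound to three saturated chain carbons, gives in this assay a 4.7-fold higher number from compound 2 to compound 4 (0.67 log units; beyond the scatter). Going by these compounds alone, this is the first direct reading of this position, since tert-butyl had so far appeared only in compounds that also differed elsewhere, and its share could not be separated from those other differences. One added methyl, a single heavy atom with no hydrogen-bond donors or acceptors, is enough to move the number beyond the usual scatter, and it moves toward lower toxicity in this test, so this place is not indifferent here.

From the compounds shown here alone, how a cyclohexyl group or a longer chain at this place would read stays open, as does whether the same methyl would give a similar step on another part of the series, and this single pair cannot say why the number rises. Compound 1 is reported only as a limit, so it gives no number against which to measure any further rise: the limit of > 50000 nM in this assay, at which 1 of the 4 values shown sits.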